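Working notes: cytotoxicity limits and an expected analogue

This account rests on a few compounds, and the source may have more. Where it says the series, first, only, none or still open, it means among the compounds named here.

The read-out throughout is an ADME assay on HCT-116 cells (Homo sapiens) for cytotoxicity, read by CellTiter-Glo, with a stated time of 72 h; on this read-out lower numbers stand for stronger inhibition and higher numbers for weaker inhibition. Compound 1 `Cc1cc(C)c(S(=O)(=O)N2CCC(C3OCC(C)CO3)CC2)c(C)c1` returns only a limit of the assay there: in this assay compound 1 gives > 5000 nM. Compound 2 `COc1ccc(S(=O)(=O)N2CCC(N3CCC(C)CC3)CC2)cc1OC` is likewise reported as a limit, giving > 5000 nM in this assay. Compound 3 `CC1CCN(C2CCN(S(=O)(=O)c3ccc(F)cc3F)CC2)CC1` also comes back as a limit, with > 5000 nM in this assay. Compound 1 thus stands at the limit of > 5000 nM in this assay, at which 3 of the 3 values shown sit, with no number that would set it apart from the other two and no order among the three that the assay can support.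

Compound 4 `Cc1cc(C)c(S(=O)(=O)N2CCC(N3CCC(C)OC3)CC2)c(C)c1` is the unmeasured partner of compound 1. The change is a group of 7 heavy atoms (5 carbon, 1 nitrogen, 1 oxygen; one six-membered non-aromatic ring with 2 hetero atoms) in place of a group of 7 heavy atoms (5 carbon, 2 oxygen; one six-membered non-aromatic ring with 2 hetero atoms), on a saturated ring carbon. For the measured compounds named here, no pair of measured compounds differs in this one place, so no measured step fixes the size of the move, and the three values that exist all stop at the same limit.

Since every measured compound rests at the limit of > 5000 nM in this assay, at which 3 of the 3 values shown sit, the expectation for compound 4 is a step that the limit leaves unreadable from compound 1 to compound 4, that is, nothing beyond the scatter. Compound 4 is estimated at 10000 nM, within a range from 4000 nM to 40000 nM, and most likely it will again be reported as a limit rather than as a number.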

Compound 4, half-maximal inhibitory concentration: > 5000 nM
Compound 4 gave a limit, no number; the forecaster's own chance of this, stated with the estimate: 80%; the middle value lies beyond the limit too.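

Compound 1 and compound 4 both return only a limit in this assay, so the step between them cannot be read and its size stays unknown: the limit of > 5000 nM in this assay, at which 4 of the 4 values shown sit.

The compounds shown leave open whether any change to the shared core would yield a number rather than a limit in this assay.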